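The source may report more compounds than this note shows. Statements on the series, on what has been measured and on what is new or still open speak of the compounds shown alone.

For the measured compounds named here, in a functional assay on MCF7 cells (Homo sapiens) for inhibition, read by MTT assay, with a stated time of 72 h (on this read-out higher numbers stand for weaker inhibition and lower numbers for stronger inhibition), compound 1 `C=C(Br)C(=O)Nc1cccc(/C=C/C(=O)Nc2ccccc2)c1` gives 27300 nM, the highest of the three numbers so far. Compound 2 `C=C(Br)C(=O)Nc1cccc(/C=C/C(=O)Nc2cccc3ccccc23)c1` gives 2800 nM, and compound 3 `C=C(Br)C(=O)Nc1cccc(/C=C/C(=O)Nc2ccc(F)c(F)c2)c1` gives 2690 nM. Compound 4 `C=C(Br)C(=O)Nc1cccc(/C=C/C(=O)Nc2ccc(OCC)cc2)c1` has not been measured yet, and it differs from compound 1 by a single change: ethoxy in place of hydrogen on an aromatic carbon. Going by the values given here, the one measured step that bears on this change is a 10-fold lower number from compound 1 to compound 3 (1.01 log units; beyond the scatter), a large step towards stronger inhibition, made by putting 3,4-difluorophenyl in place of phenyl on an amide-type nitrogen. Ethoxy is a different group, so that step is only a loose guide. A smaller step in the same direction is expected, an estimated 3.9-fold lower number from compound 1 to compound 4 (0.59 log units; beyond the scatter). For compound 4 the estimated value is 7000 nM, with an expected range from 2000 nM to 22000 nM.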

Compound 4, half-maximal inhibitory concentration: 5500 nM
For compound 4 the middle estimate is 1.3-fold (0.10 log units) above the measured one, and the stated range covers the measured number.
By their numbers in this assay, from the lowest: compounds 3, 2 and 4 (each within the scatter of the next, the first and the last beyond it); then compound 1.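

Placing ethoxy on an aromatic carbon, para to a large group, gives a 5.0-fold lower number from compound 1 to compound 4 (0.70 log units; beyond the scatter) in this assay. This shows that one added group at this position, with the rest of compound 1 unchanged, is enough to move the number beyond the scatter towards stronger inhibition. Nothing measured here explains this step.

From the compounds shown here alone, it remains open whether methoxy, butoxy or an amine at this position would give a lower or higher number than ethoxy. Going by these compounds, it is also open whether ethoxy on another carbon of the ring would produce a similar step.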